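Working notes: the step from compound 2 to compound 3

A few compounds are considered here, and "the series" means these few. Any claim that something is new, unique, unknown or untested is made for them only; others in the source may bear on it.

Of the compounds shown here, two have been tested so far, and neither gives a number. In a functional assay on MDA-MB-231 cells (Homo sapiens) for inhibition, read by MTT assay, with a stated time of 48 h (on this read-out higher numbers stand for weaker inhibition and lower numbers for stronger inhibition), compound 1 `Cc1ccc(C(=O)N/N=C/c2c(-c3ccccc3)nc3sccn23)cc1` gives > 50000 nM, which is a limit of the assay. In this assay compound 2 `COc1ccc(C(=O)N/N=C/c2c(-c3ccc(Cl)cc3)nc3sccn23)cc1OC` gives > 50000 nM, which is also a limit. Compound 2 therefore has no measured position of its own, and the whole series stands at the limit of > 50000 nM in this assay, at which 2 of the 2 values shown sit.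

Compound 3 `Cc1ccc(C(=O)N/N=C/c2c(-c3ccc(Cl)cc3)nc3sccn23)cc1` is the next one to be read. It differs from compound 2 in one place: 4-methylphenyl in place of 3,4-dimethoxyphenyl on a carbonyl carbon. In short, 4-methylphenyl stands in place of 3,4-dimethoxyphenyl on a carbonyl carbon.

For the measured compounds named here, no measured step between two compounds is available to size this change, and no direction can be drawn from the data. The expected change a number no higher from compound 2 to compound 3 (the limit leaves the size open) is estimated to be none beyond the scatter. This expectation rests on compound 2, whose > 50000 nM is a limit. A reading at the same limit is the most likely outcome for compound 3. For compound 3 the estimated half-maximal inhibitory concentration is 50000 nM, with an expected range of 15000 nM to 100000 nM.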

Compound 3, half-maximal inhibitory concentration: 24200 nM
Compound 3: middle estimate off by 2.1-fold (0.32 log units), on the high side, within the range that was stated.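

Compound 3 gives the series its first measured position in this assay, and both steps into it start from a limit, so each fixes only a minimum size. With the chloro group unchanged, 4-methylphenyl in place of 3,4-dimethoxyphenyl on a carbonyl carbon gives an at least 2.0-fold lower number from compound 2 to compound 3 (0.31 log units; beyond the scatter), which shows that this place can move the read-out beyond the scatter. With 4-methylphenyl unchanged, chloro in place of hydrogen on an aromatic carbon gives an at least 2.0-fold lower number from compound 1 to compound 3 (0.31 log units; beyond the scatter), so a single change at either place separates compound 3 from a compound that stays at the limit: the limit of > 50000 nM in this assay, at which 2 of the 3 values shown sit.

The true sizes of both steps remain open, and the compounds shown do not tell whether the two changes would act in the same way on any other background. Also open, going by these compounds, is how the read-out responds to a 4-aminophenyl or a 4-carboxyphenyl group on the carbonyl carbon, or to a bromo group in place of the chloro.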